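Silyl ether removal on a tetrahydropyran ester scaffold

The source may hold more compounds than are shown below. What is called first, only, known or untested is meant among the compounds shown, and "the series" means these compounds.

Compound 1 `CC(C)(C)[Si](C)(C)OC[C@H]1OCCC[C@H]1O[Si](C)(C)C(C)(C)C` carries two silyl ethers on its shared core. In a functional assay on SW1573 cells (Homo sapiens) for antiproliferative activity, read by sulforhodamine B assay, with a stated time of 48 h (on this read-out higher numbers stand for weaker inhibition of growth and lower numbers for stronger inhibition of growth), compound 1 gives only a limit of the assay, > 100000 nM. Compound 2 `CC(C)(C)[Si](C)(C)O[C@@H]1CCCO[C@@H]1CO` differs by a hydrogen atom in place of a group of 7 heavy atoms (6 carbon, 1 silicon; no ring), on an oxygen on a saturated carbon. In this assay compound 2 likewise reaches only a limit, > 100000 nM. The step that the two limits leave unreadable from compound 1 to compound 2 is therefore not readable, since the limit of > 100000 nM in this assay, at which 2 of the 3 values shown sit, holds both values. Compound 3 `CC(C)(C)[Si](C)(C)O[C@@H]1CCCO[C@@H]1CC(=O)OCc1ccccc1` has a core whose difference from compound 1 is not broken down here. In this assay, going by the values given here, compound 3 gives 30000 nM, the only number among the three. Compound 4 `O=C(C[C@H]1OCCC[C@H]1O)OCc1ccccc1` differs from compound 3 by a hydrogen atom in place of a group of 7 heavy atoms (6 carbon, 1 silicon; no ring), on an oxygen on a saturated carbon, the same kind of change as from compound 1 to compound 2, though here the oxygen sits on a saturated carbon whose other neighbour is a saturated ring carbon rather than a saturated chain carbon. No readable precedent exists, so the expected step of a 2.7-fold higher number from compound 3 to compound 4 (0.43 log units; beyond the scatter) is set cautiously toward weaker growth inhibition. Compound 4 is estimated at 80000 nM, between 25000 nM and 200000 nM, with a real chance that only a limit is recorded.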

Compound 4, concentration for 50% growth inhibition: > 100000 nM
Compound 4: only a limit was reported; the forecaster's own chance of this, stated with the estimate: 40%; middle value at least 1.2-fold (0.09 log units) from the limit.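

In this assay, a hydrogen atom in place of the group of 7 heavy atoms gives an at least 3.3-fold higher number from compound 3 to compound 4 (0.52 log units; beyond the scatter), so on the core of compound 3 this change goes with weaker growth inhibition. The same change on the core of compound 1 cannot be read, so nothing here shows whether the effect carries from one core to another. The step from compound 3 is also only a minimum, and the comparison ends at a limit of the assay: the limit of > 100000 nM in this assay, at which 3 of the 4 values shown sit.

The compounds shown leave open how a methyl ether or an acetate ester on that oxygen would read on the core of compound 3. They also leave open how a carboxylic acid would read in place of the benzyl ester.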